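This account rests on a few compounds, and the source may have more. Where it says the series, first, only, none or still open, it means among the compounds named here.

Compound 1 `COc1ccc(N/C=C\C(=O)c2nc(-c3ccc(C(F)(F)F)cc3)n3ccccc23)cc1OC` gives, in a functional assay on A549 cells (Homo sapiens) for cytotoxicity, read by MTT assay, with a stated time of 48 h (on this read-out lower numbers stand for stronger inhibition and higher numbers for weaker inhibition), only the assay limit of > 30000 nM and no number. Compound 2 `O=C(/C=C\Nc1cnc2ccccc2c1)c1nc(-c2ccccc2)n2ccccc12` likewise returns a limit of > 30000 nM in this assay. Compound 3 `COc1ccc(-c2nc(C(=O)/C=C\Nc3ccc(F)cc3)c3ccccn23)cc1` also stops at a limit of > 30000 nM in this assay. Going by the values given here, every value shown therefore sits at the same limit (the limit of > 30000 nM in this assay, at which 3 of the 3 values shown sit), so compound 1 cannot be placed relative to the others, and no step between measured compounds is available. Compound 4 `COc1ccc(N/C=C\C(=O)c2nc(-c3ccc(C(F)(F)F)cc3)n3ccccc23)cc1` differs from compound 1 by hydrogen in place of methoxy on an aromatic carbon. With three compounds of the series all at the limit, the step from compound 1 to compound 4 is expected to be none beyond the scatter, with compound 4 most likely remaining at a limit. The estimated step that the limit leaves unreadable from compound 1 to compound 4 carries that expectation. Compound 4 is expected near 50000 nM, within 20000 nM to 200000 nM.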

Compound 4, half-maximal inhibitory concentration: 21800 nM
Estimate against measurement, compound 4: 2.3-fold (0.36 log units) above, within the range that was stated.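

In this assay compound 4 gives 21800 nM, the only measured number among the compounds shown rather than a limit. Going from 3,4-dimethoxyphenyl to 4-methoxyphenyl, with hydrogen in place of methoxy on the aromatic carbon, gives an at least 1.3-fold lower number from compound 1 to compound 4 (0.13 log units; that floor lies within the scatter), so this position yields only a floor and no true size of change. Most of the series still gives no number: the limit of > 30000 nM in this assay, at which 3 of the 4 values shown sit.

On these data alone, how this position responds to anything other than methoxy or hydrogen, such as a hydroxyl, an amine or a carboxylic acid, remains open. Also open, as far as these compounds go, is whether the remaining methoxy group contributes to the value of compound 4.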